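From Methyl to Fluoro on a Glucosidase Assay

The source may hold more compounds than are shown below. What is called first, only, known or untested is meant among the compounds shown, and "the series" means these compounds.

Compound 1 `Cc1cccc(/C=C2\CCC/C(=C\c3ccccc3)C2=O)c1` was tested in an assay on isolated protein for inhibition of Alpha glucosidase (Homo sapiens), with stated times of 5 min and 15 min, tested at 50 uM (on this read-out higher numbers stand for more inhibition at the one concentration tested (going by the name of the read-out) and lower numbers for less inhibition), and gives 47.9%. That is the highest of the three numbers in hand, though only within the scatter: compound 2 `O=C(/C=C(O)/C=C/c1ccc(O)cc1)c1cc(Cl)ccc1O` gives 45.3% and compound 3 `O=C1/C(=C/c2ccccc2)CCC/C1=C\c1cccc(Cl)c1Cl` gives 44%, so the three cannot be told apart on this assay. The untested compound 4 `O=C1/C(=C/c2ccccc2)CCC/C1=C\c1cccc(F)c1` differs from compound 1 in one place: fluoro in place of methyl on an aromatic carbon. Going by the values given here, no pair among the measured compounds shows what such a change does, so nothing points to a shift beyond the scatter in either direction. The step is therefore expected to be a number 2.9 percentage points lower from compound 1 to compound 4 (within the scatter), none beyond the scatter. The estimate for compound 4 is 45%, ranging from 30% to 60%.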

Compound 4, a percentage reported as inhibition, at one concentration (the size of the read-out at that concentration, not a potency): 39.8%
The estimate for compound 4 lay 5.2 percentage points above the measured number, within the range that was stated.
By their numbers in this assay, from the lowest: compounds 4, 3, 2 and 1 (each within the scatter of the next).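

Going by these compounds alone, this is the first comparison here in which only one group changes: fluoro in place of methyl on this aromatic carbon gives a number 8.1 percentage points lower from compound 1 to compound 4 (within the scatter) in this assay. The two compounds therefore cannot be told apart, and at the one concentration tested this position accepts either group. Nothing measured here bears on the reason for this result.

Still open, from the compounds shown here alone, is what an amine, a carboxylic acid or a methoxy group at the same position would give. A single pair also cannot show whether this swap would behave alike elsewhere on the shared core.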